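Methoxy for methyl on the aryl triazole of compound 3

The source may hold more compounds than are shown below. What is called first, only, known or untested is meant among the compounds shown, and "the series" means these compounds.

Measured so far in a functional assay on A549 cells (Homo sapiens) for cytotoxicity, read by MTT assay, with a stated time of 4 days; on this read-out higher numbers stand for weaker inhibition and lower numbers for stronger inhibition:
- compound 1 `Cc1ccc(S(=O)(=O)Oc2ccc3c(c2C)[C@H](Cn2cc(-c4ccc(C(F)(F)F)cc4)nn2)[C@@]24CC(=O)[C@@](C)(CC[C@@H]32)C4)cc1`: > 20000 nM
- compound 2 `C=C1C(=O)[C@]23C[C@@]1(O)CC[C@H]2c1ccc(O)c(C)c1[C@@H]3Cn1cc(-c2ccc(C)cc2)nn1`: 1260 nM
- compound 3 `C=C1C(=O)[C@]23C[C@@]1(O)CC[C@H]2c1ccc(OS(=O)(=O)c2ccc(C)cc2)c(C)c1[C@@H]3Cn1cc(-c2ccc(C)cc2)nn1`: 1830 nM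

Compound 3 has the highest of the two numbers; its nearest neighbour is compound 2, and the step of a 1.5-fold higher number from compound 2 to compound 3 (0.16 log units; within the scatter) lies within the scatter, so the two compounds cannot be told apart on this read-out. The value given for compound 1 is a limit of this assay, not a number.

Compound 4 `C=C1C(=O)[C@]23C[C@@]1(O)CC[C@H]2c1ccc(OS(=O)(=O)c2ccc(C)cc2)c(C)c1[C@@H]3Cn1cc(-c2ccc(OC)cc2)nn1` differs from compound 3 in one place: methoxy in place of methyl on an aromatic carbon. Within the data shown here, none of the measured steps bears on this change. Among the measured compounds shown here, the only step with a number, the change of tosyl for hydrogen on the phenol oxygen, touches another part of the molecule, and compound 1 differs from compound 3 in more than one place, so its limit says nothing on its own about the methyl to methoxy exchange. With no guidance from the data, compound 4 is expected to sit close to compound 3, with a step of a 1.1-fold higher number from compound 3 to compound 4 (0.04 log units; within the scatter) of no more than the scatter in either direction. The estimate for compound 4 in this assay is therefore 2000 nM, with a range from 800 nM to 5000 nM.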

Compound 4, half-maximal inhibitory concentration: 1470 nM
For compound 4 the middle estimate is 1.4-fold (0.13 log units) above the measured one; the range from low to high includes it.
By their numbers in this assay, from the lowest: compounds 2, 4 and 3 (each within the scatter of the next). At a limit, above all of these: compound 1.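

In this assay, the step from a methyl to a methoxy on the aromatic ring is a 1.2-fold lower number from compound 3 to compound 4 (0.10 log units; within the scatter), so the two compounds cannot be told apart on this read-out. Among these compounds, this is the first measured step at this position, as the earlier step with a number concerned the oxygen on the other aromatic ring, and it shows that this position can take methoxy in place of methyl with no change that the read-out can detect. Nothing in the data shown accounts for this result.

As far as these compounds go, whether an amine or a carboxylic acid at this position would leave the number within the same scatter remains open. Compound 1 carries trifluoromethyl at this position but differs from compound 3 in more than one place, so it cannot settle what this position alone allows.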